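The source may hold more compounds than are shown below. What is called first, only, known or untested is meant among the compounds shown, and "the series" means these compounds.

Compound 1 `COCc1nc2nc(C)cc(Nc3ccc(S(F)(F)(F)(F)F)cc3)n2n1` is examined in an ADME assay on a cell-free system (plasma, Homo sapiens) for protein binding, where compound 1 gives 91.7%. Two relatives set the frame. Compound 2 `COCc1nc2nc(C)cc(Nc3ccc(C(F)(F)F)cc3)n2n1` carries a trifluoromethyl group where compound 1 carries its pentafluorosulfanyl group; in this assay compound 2 gives 75.6%, so that there is a 2.9-fold higher unbound fraction from compound 1 to compound 2 (0.47 log units; beyond the scatter). Compound 3 `Cc1cc(Nc2cccc(Cl)c2)n2nc(C(C)(F)F)nc2n1`, built on a different pattern, gives 88.2%; its value and that of compound 1 lie within the scatter of each other, so nothing can be said of their order. Among the three values, compound 1 sits at the bound end, and only compound 2 is separated from it beyond the scatter.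

Compound 4 `CCOc1nc2nc(C)cc(Nc3ccc(S(F)(F)(F)(F)F)cc3)n2n1` differs from compound 1 in the group on the five-membered ring of the shared core: ethoxy in place of methoxymethyl on an aromatic carbon. Going by the values given here, the only measured step concerns the group on the aniline ring and therefore does not bear on this change; the set holds no pair in which the substituent on the five-membered ring is varied alone. With no guidance from a matching step, the expectation is a change in this assay that stays within the scatter, a 1.1-fold higher unbound fraction from compound 1 to compound 4 (0.04 log units; within the scatter). Compound 4 is therefore expected to give about 91%, in the range from 84% to 95.5%.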

Compound 4, plasma protein binding: 97.7%
Compound 4: middle estimate off by 3.9-fold (0.59 log units) (unbound fraction), on the high side; the whole stated range lies below it.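

The exchange of methoxymethyl for ethoxy on an aromatic carbon of the five-membered aromatic ring leaves the counts of heavy atoms, rings, hydrogen-bond donors and hydrogen-bond acceptors unchanged, yet in this assay it gives a 3.6-fold lower unbound fraction from compound 1 to compound 4 (0.56 log units; beyond the scatter), so the way the same atoms are joined at this position can by itself shift the read-out beyond the scatter. This position therefore joins the group on the other ring as a place where a single change to compound 1 matters, and the two changes run in opposite directions, the earlier one, trifluoromethyl in place of pentafluorosulfanyl, giving a 2.9-fold higher unbound fraction from compound 1 to compound 2 (0.47 log units; beyond the scatter). Nothing in the data shown accounts for the difference between the two groups.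

On these data alone, it remains open whether the shift is particular to ethoxy or would extend to a longer chain such as propoxy, to a methoxy group or to an amine at the same place. Going by these compounds alone, the step is also seen only with pentafluorosulfanyl on the shared core, and whether the same exchange would move the read-out similarly in a trifluoromethyl compound is unsettled.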